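Working notes on compound 3 against compounds 1 and 2

The source may hold more compounds than are shown below. What is called first, only, known or untested is meant among the compounds shown, and "the series" means these compounds.

Measured so far:
compound 1, `COc1cc(-c2cc(/C=C/C(=O)c3ccc(N)cc3)[nH]n2)cc(OC)c1OC`, 96%
compound 2, `COc1ccc(-c2cc(/C=C/C(=O)c3ccc(N)cc3)[nH]n2)cc1OC`, 97%

Both values come from a functional assay on A549 cells (Homo sapiens) for cytotoxicity, read by sulforhodamine B assay, with a stated time of 48 h, tested at 0.01 uM; a lower number here means a stronger effect, a higher number a weaker effect of the compound at the concentration tested. Compound 1 stands at the lower of the two numbers, and its nearest neighbour is compound 2, with a number 1 percentage points higher from compound 1 to compound 2 (within the scatter); the two therefore cannot be told apart on this read-out. That step is the only one measured, and it sits on the other aromatic ring of the shared core, not at the carbonyl carbon.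

Compound 3, `COc1ccc(C(=O)/C=C/c2cc(-c3cc(OC)c(OC)c(OC)c3)n[nH]2)cc1OC`, has not yet been measured. Relative to compound 1 the change is 3,4-dimethoxyphenyl in place of 4-aminophenyl on a carbonyl carbon. Among the measured compounds shown here, no measured step touches the aryl group on the carbonyl carbon, so the expectation for compound 3 in this assay can only lean on the flat picture given by compounds 1 and 2: a step of a number 1 percentage points lower from compound 1 to compound 3 (within the scatter) is expected, with no move beyond the scatter. Compound 3 is therefore estimated at 95%, with a range from 84% to 101%.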

Compound 3, a percentage reported as activity, at one concentration (the size of the read-out at that concentration, not a potency): 98%
The estimate for compound 3 lay 3 percentage points below the measured number; measured number inside the range.
By their numbers in this assay, from the lowest: compounds 1, 2 and 3 (each within the scatter of the next).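

In this assay, among the compounds shown here, the aryl group on the carbonyl carbon is varied for the first time, and 3,4-dimethoxyphenyl in place of 4-aminophenyl gives a number 2 percentage points higher from compound 1 to compound 3 (within the scatter). The read-out at this position therefore does not depend on keeping the amine of 4-aminophenyl, even though the entering group is larger by heavy-atom count and swaps that amine for two methoxy groups. For the compounds shown here, the flat picture, previously seen only on the other aromatic ring, now also covers this position, though only at the one concentration tested. Nothing available bears on why this change leaves the read-out within the scatter.

Because the numbers for compound 1 and compound 3 lie within the scatter of each other at a single concentration, this read-out cannot show whether the two aryl groups would separate under conditions where the compounds produce a clear effect. It also leaves open whether a carboxylic acid or a trifluoromethyl group on the aryl ring attached to the carbonyl carbon would move the number beyond the scatter in this assay.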